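The source may report more compounds than this note shows. Statements on the series, on what has been measured and on what is new or still open speak of the compounds shown alone.

Measured so far in a functional assay on BXPC-3 cells (Homo sapiens) for cytotoxicity, read by fluorescence, with a stated time of 48 h; a higher number here means that more compound is needed for the effect, a lower number that less compound is needed
- compound 1 `CC(C)=CCC/C(C)=C/CC/C(C)=C/CSC[C@H](NC(=O)CCCCCN1CCCC1)C(=O)NC1CCCCCC1` gives 5800 nM
- compound 2 `CC(C)=CCC/C(C)=C/CC/C(C)=C/CSC[C@H](NC(=O)CCCCCN1CCCC1)C(=O)NC1CCCCCCC1` gives 4000 nM

Compound 2 stands within the scatter of compound 1 and the two cannot be ranked. Still unmeasured is compound 3 `CC(C)=CCC/C(C)=C/CC/C(C)=C/CSC[C@H](NC(=O)CCCCCN1CCCC1)C(=O)NC1CC1`. The change from compound 2 is cyclopropyl in place of cyclooctyl on an amide-type nitrogen, on an amide-type nitrogen. Among the measured compounds shown here, the only measured step bearing on it is a 1.5-fold lower number from compound 1 to compound 2 (0.16 log units; within the scatter). That step is within the scatter and spans only cycloheptyl to cyclooctyl, so it gives weak guidance for cyclopropyl. A modest move to a higher number is expected, as a 2.3-fold higher number from compound 2 to compound 3 (0.35 log units; beyond the scatter). For compound 3 the estimated value is 9000 nM, with an expected range from 3500 nM to 25000 nM.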

Compound 3, half-maximal effective concentration: > 20000 nM
Compound 3 ended at the assay's limit; the forecaster's own chance of this, stated with the estimate: 15%; middle value at least 2.2-fold (0.34 log units) from the limit.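

On the amide-type nitrogen, ring size now registers in this assay: cyclopropyl gives an at least 5.0-fold higher number from compound 2 to compound 3 (0.69 log units; beyond the scatter) and an at least 3.4-fold higher number from compound 1 to compound 3 (0.53 log units; beyond the scatter), whereas the cycloheptyl to cyclooctyl step stayed within the scatter. The value of compound 3, > 20000 nM, is a limit of the assay and not a number. Both new steps therefore give minimum sizes only: the limit of > 20000 nM in this assay, at which 1 of the 3 values shown sits.

Open, from the compounds shown here alone, is where cyclopentyl or cyclohexyl on this nitrogen would fall between these ends of the series. Also open, going by these compounds, is whether an open-chain group such as tert-butyl would read with cyclopropyl or with cycloheptyl and cyclooctyl.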